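Flipping One Ring Stereocentre: Expected Effect on Lipophilicity

The compounds below may be only part of what the source reports. "The series", "measured", "known", "first", "only" and "open" are said of these compounds alone.

Measured compounds:
- compound 1, `CCc1ccc(N(CC2CCC2)S(=O)(=O)c2ccc3c(c2)C(O)CC(C2CCOCC2)O3)cc1`: 4.01
- compound 2, `CCc1ccc(N(CC(C)C)S(=O)(=O)c2ccc3c(c2)CCC3OC2CCOCC2)cc1`: 4.96
- compound 3, `CCc1ccc(N(CC(C)C)S(=O)(=O)c2ccc3c(c2)C(O)C[C@H](C2CCOCC2)O3)cc1`: 4.12

The read-out throughout is a physicochemical assay for lipophilicity, at pH 7.4; on this read-out higher numbers stand for higher lipophilicity and lower numbers for lower lipophilicity. Among the three measured compounds, compound 3 holds the second highest number. Compound 1 sits nearest to it, with a value that lies within the usual scatter of this assay, so the two cannot be told apart on these numbers. Compound 2 lies furthest away, with a value beyond the scatter and higher than that of compound 3.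

The unmeasured compound 4, `CCc1ccc(N(CC(C)C)S(=O)(=O)c2ccc3c(c2)C(O)C[C@@H](C2CCOCC2)O3)cc1`, is built from compound 3 by a single change: the two compounds have the same atoms and bonds; at least one stereo element is drawn with a configuration in one of them and without one in the other: 1 of 2 stereo elements differ; a stereocentre at a saturated ring carbon is drawn R in compound 3 and S in compound 4. No atom leaves and none enters; only the drawn configuration at that one saturated ring carbon is swapped.

Going by the values given here, no pair of measured compounds shares exactly this kind of difference, so there is no measured step to lean on. Since the atoms and bonds are identical, the expectation is that compound 4 will give a number that does not move beyond the scatter in either direction. The expected step is no change at the digits printed from compound 3 to compound 4 (within the scatter), which lies within the usual scatter. Compound 4 is therefore estimated at 4.12, with a range from 3.85 to 4.4.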

Compound 4, distribution coefficient: 4.12
The estimate for compound 4 equals the measured number at the digits printed; low and high end bracket the measured number.
By their numbers in this assay, from the lowest: compounds 1, 3 and 4 (each within the scatter of the next); then compound 2.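

In this assay, swapping the drawn configuration at the saturated ring carbon gives no change at the digits printed from compound 3 to compound 4 (within the scatter). This is the only pair shown that differs in one place, so it isolates a single structural change in a way the earlier compounds could not: with the same atoms and bonds, compound 3 reads 4.12 and compound 4 reads 4.12, and at this position the read-out does not tell the two drawings apart. This reading carries a caution, as the comparison may not be one between two fully defined forms, and that caution rests on one point: the fact that one of compounds 3 and 4 is drawn with a defined configuration and the other without, at the place where they differ

The compounds shown leave open whether the same swap at this carbon would read the same way in a compound carrying an amine or a carboxylic acid elsewhere on the shared core. They also leave open whether the two drawn forms would stay level in any kind of measurement beyond this assay, since one pair in one read-out cannot settle that.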